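The compounds below may be only part of what the source reports. "The series", "measured", "known", "first", "only" and "open" are said of these compounds alone.

Among the compounds with values here, in a functional assay on PC-3 cells (Homo sapiens) for antiproliferative activity (on this read-out higher numbers stand for weaker inhibition and lower numbers for stronger inhibition), compound 2 `COc1ccc(-c2csc(N/N=C(\C)c3cc4ccccc4o3)n2)cc1` gives 28900 nM, one of only two numbers recorded so far, with compound 1 `C/C(=N\Nc1nc(-c2ccc(Cl)cc2)cs1)c1cc2ccccc2o1` close to it at 38100 nM in this assay. Within the data shown here, the sole step bearing on this position, a 1.3-fold lower number from compound 1 to compound 2 (0.12 log units; within the scatter), lies within the scatter, so the group on that six-membered ring has so far made no visible difference. Compound 3 `C/C(=N\Nc1nc(-c2ccccc2)cs1)c1cc2ccccc2o1` differs from compound 2 by hydrogen in place of methoxy on an aromatic carbon. On that evidence no step beyond the scatter is expected in this assay. Compound 3 is therefore estimated at 35000 nM, between 15000 nM and 80000 nM, which would amount to a 1.2-fold higher number from compound 2 to compound 3 (0.08 log units; within the scatter).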

Compound 3, half-maximal inhibitory concentration: 16700 nM
The estimate for compound 3 lay 2.1-fold (0.32 log units) above the measured number; the range from low to high includes it.
By their numbers in this assay, from the lowest: compounds 3, 2 and 1 (each within the scatter of the next, the first and the last beyond it).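

In this assay, within the data shown here, phenyl gives the first step at this position that lies beyond the scatter, a modest one (a 2.3-fold lower number from compound 1 to compound 3 (0.36 log units; beyond the scatter)), whereas the step from methoxy to hydrogen stays within it (a 1.7-fold lower number from compound 2 to compound 3 (0.24 log units; within the scatter)). Hydrogen is thus separated from chloro but not from methoxy, and methoxy and chloro remain within the scatter of each other. Nothing at hand bears on the reason for this step.

As far as these compounds go, whether an amine or a carboxylic acid on this carbon would give a larger step remains open. Also open, from the compounds shown here alone, is whether hydrogen in place of chloro gives a similar step on another core.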